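The source may hold more compounds than are shown below. What is called first, only, known or untested is meant among the compounds shown, and "the series" means these compounds.

Compound 1 `CCC(=O)NC(c1ccco1)c1cc(Cl)c2cccnc2c1O`: 1000 nM
Compound 2 `CCC(=O)NC(c1ccc(C)s1)c1cc(Cl)c2cccnc2c1O`: 3500 nM

For the measured compounds named here, in an assay for inhibition of Polyunsaturated fatty acid lipoxygenase ALOX12 (Homo sapiens), read by spectrophotometry (a lower number here means a stronger inhibitor, a higher number a weaker inhibitor), compound 1 gives 1000 nM, the lowest of the two numbers measured so far. Going by the values given here, its nearest neighbour is compound 2, which in this assay gives 3500 nM; the only measured step, a 3.5-fold higher number from compound 1 to compound 2 (0.54 log units; beyond the scatter), exchanges the group on the saturated chain carbon bound to the amide-type nitrogen and the aromatic carbon.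

Compound 3 `O=C(NC(c1ccco1)c1cc(Cl)c2cccnc2c1O)c1ccccc1` has not yet been measured in this assay. It differs from compound 1 in a different place: phenyl in place of ethyl on a carbonyl carbon. Among the compounds with values here, no measured step touches the carbonyl carbon, so the single step from compound 1 to compound 2 cannot be read as a guide for this change, and the direction of the step is open on the present data. The estimate for compound 3 therefore sits close to the number of compound 1, with a wide range: compound 3 is expected to give about 1000 nM in this assay, between 300 nM and 3500 nM, which corresponds to an expected step of no change at the digits printed from compound 1 to compound 3 (within the scatter).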

Compound 3, half-maximal inhibitory concentration: > 25000 nM
Compound 3: no number, only a limit; the forecaster's own chance of this, stated with the estimate: 5%; middle value at least 25-fold (1.39 log units) away from the limit.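

In this assay, the carbonyl carbon turns out to be a place where the compounds respond strongly: phenyl in place of ethyl there gives an at least 25-fold higher number from compound 1 to compound 3 (1.39 log units; beyond the scatter). For the compounds shown here, the only earlier step, a 3.5-fold higher number from compound 1 to compound 2 (0.54 log units; beyond the scatter), lay on the saturated chain carbon and was modest, so the first two compounds gave no sign that a single change on the carbonyl carbon could cost this much. The value of compound 3 is a limit of the assay and not a number: the limit of > 25000 nM in this assay, at which 1 of the 3 values shown sits.

The compounds shown do not tell whether the loss goes with the aromatic ring of the benzoyl group or with any group beyond ethyl on the carbonyl carbon, and an acetyl group, a longer chain such as butanoyl or a saturated ring such as cyclohexyl could each separate these readings. As far as these compounds go, it also stays open whether benzoyl in place of propanoyl would cost as much with the 5-methylthiophen-2-yl group of compound 2 on the saturated chain carbon.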